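The source may report more compounds than this note shows. Statements on the series, on what has been measured and on what is new or still open speak of the compounds shown alone.

Measured compounds:
- compound 1, `CCCCCNc1nc(NCc2ccco2)c2cc(F)ccc2n1`: 7340 nM in a functional assay on A375P cells (Homo sapiens) for cytotoxicity, read by MTT assay, with a stated time of 2 days; a lower number here means a stronger inhibitor, a higher number a weaker inhibitor
- compound 2, `Cc1cccc(N2CCN(CCCCNc3nc(NCc4ccco4)c4ccccc4n3)CC2)c1C`: 3900 nM in this assay
- compound 3, `Fc1ccc2nc(NCCCCN3CCN(c4cccc(Cl)c4Cl)CC3)nc(NCc3ccco3)c2c1`: 2650 nM in this assay

Of the compounds shown here, three built on the same core have been tested in this assay. Compound 1 has the highest number of the three. Compound 2 sits close to it, within the scatter of the method, so the two cannot be told apart. Compound 3 gives the lowest number, and its gap to compound 1 lies beyond the scatter, so compound 3 is the stronger of those two.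

Compound 4, `COc1ccc(Nc2nc(NCc3ccco3)c3cc(F)ccc3n2)cc1`, has not yet been measured. It differs from compound 1 in one place: 4-methoxyphenyl in place of pentyl on a nitrogen on an aromatic ring. Within the data shown here, no measured pair in this set shows this kind of change, so there is nothing to lean on for its size or direction. Compound 2 and compound 3 show that a larger group in the same region of the core goes with a somewhat lower number, but those groups are quite different from the one entering here. A modest step in this assay, in either direction, seems the most likely outcome, and no step beyond the scatter would be a surprise.

Compound 4 is expected to give about 5000 nM, with a likely range from 1500 nM to 15000 nM. This expectation means a step of a 1.5-fold lower number from compound 1 to compound 4 (0.17 log units; within the scatter).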

Compound 4, half-maximal inhibitory concentration: 7660 nM
Beside the measured number, compound 4's estimate is 1.5-fold (0.19 log units) below it; the range from low to high includes it.
By their numbers in this assay, from the lowest: compounds 3, 2, 1 and 4 (each within the scatter of the next, the first and the last beyond it).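

In this assay, among these compounds, this is the first direct reading of a change at this position: 4-methoxyphenyl in place of pentyl on a nitrogen on an aromatic ring gives a 1.0-fold higher number from compound 1 to compound 4 (0.02 log units; within the scatter). An aromatic ring carrying a methoxy group can therefore take the place of the open pentyl chain on this nitrogen with no difference the assay can resolve. No evidence at hand accounts for this result.

Going by these compounds, it remains open whether a plain phenyl, a pyridine ring or a carboxylic acid on this nitrogen would also stay within the scatter of compound 1. On these data alone, it is also open whether the same swap would read alike on a core that lacks the fluorine of compound 1.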